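Trimming the Amine Substituent Further on a Shared Core

A few compounds are considered here, and "the series" means these few. Any claim that something is new, unique, unknown or untested is made for them only; others in the source may bear on it.

Measured compounds:
compound 1 `COC[C@H](NC1CCN(CCCc2c[nH]c3ccc(-n4cnnc4)cc23)CC1)c1ccccc1`: 0.9 nM
compound 2 `C[C@@H](NC1CCN(CCCc2c[nH]c3ccc(-n4cnnc4)cc23)CC1)c1ccccc1`: 13 nM

Both compounds were tested in an assay on CHO cells for agonist activity at 5-hydroxytryptamine receptor 1D (Homo sapiens), read by GTPgammaS binding; a lower number here means that less compound is needed, a higher number that more compound is needed for the effect. Within the data shown here, only one measured step connects them: a 14-fold higher number from compound 1 to compound 2 (1.16 log units; beyond the scatter), where the 2-methoxy-1-phenylethyl group on the amine nitrogen was cut back to 1-phenylethyl. Among the measured compounds shown here, on the two numbers available, compound 2 therefore stands highest, with compound 1 as its only neighbour, far below it.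

Compound 3 `CC(C)=CCN(C)C1CCN(CCCc2c[nH]c3ccc(-n4cnnc4)cc23)CC1` goes further in the same place. It differs from compound 2 by methyl(3-methylbut-2-en-1-yl)amino in place of (1-phenylethyl)amino on a saturated ring carbon: the aromatic ring and the hydrogen-bond donor of the amine are gone, and a methyl and a branched alkenyl chain take their place. For the measured compounds named here, the one measured step bears on this change only indirectly, since it concerned a smaller alteration of the same substituent, yet it was large and ran towards a higher number. A step of a similar kind, and likely in the same direction, is expected here. Compound 3 is estimated at 60 nM, within 12 nM to 300 nM, which corresponds to an expected step of a 4.6-fold higher number from compound 2 to compound 3 (0.66 log units; beyond the scatter).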

Compound 3, half-maximal effective concentration: 1.8 nM
The estimate for compound 3 lay 33-fold (1.52 log units) above the measured number; the measured number lies below the stated range.
By their numbers in this assay, from the lowest: compounds 1 and 3 (each within the scatter of the next); then compound 2.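

In this assay, the step of a 7.2-fold lower number from compound 2 to compound 3 (0.86 log units; beyond the scatter) shows that the substituent on this saturated ring carbon can give up its six-membered aromatic ring, its hydrogen-bond donor and its defined stereocentre all at once while the number still falls, so cutting back at this place does not lead only to higher numbers. The comparison with the larger group gives a 2.0-fold higher number from compound 1 to compound 3 (0.30 log units; within the scatter), which means that an open-chain methyl(3-methylbut-2-en-1-yl)amino group, with no ring, cannot be told apart here from (2-methoxy-1-phenylethyl)amino, and the aromatic ring is thus not needed for a low number on the shared core. Nothing at hand explains these results.

Several features change together in this step, so the compounds shown cannot say which of them accounts for it. Going by these compounds, it remains open how a saturated 3-methylbutyl chain, without the double bond, or a methyl(1-phenylethyl)amino group, which would remove the amine hydrogen but keep the aromatic ring, would read at this place.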